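The source may report more compounds than this note shows. Statements on the series, on what has been measured and on what is new or still open speak of the compounds shown alone.

Of the compounds shown here, two have so far been tested in a functional assay on HL-60 cells (Homo sapiens) for cytotoxicity, read by MTT assay, with a stated time of 48 h; a lower number here means a stronger inhibitor, a higher number a weaker inhibitor. Compound 1, `CCO[C@@]1(CC)CCC2(CO1)[C@@H]1CCC3=C4[C@@H](CC3=O)[C@H](C(=O)OC)C[C@@]42CN(C)C1`, gives > 40000 nM, which is a limit of the assay rather than a number. Compound 2, `CC[C@]1(OC)CCC2(CO1)[C@@H]1CCC3=C4[C@H](CC3=O)[C@H](C(=O)OC)C[C@@]42CN(C)C1`, gives > 40000 nM in this assay, and this too is a limit rather than a measured number. The whole picture so far is the limit of > 40000 nM in this assay, at which 2 of the 2 values shown sit. Within the data shown here, compound 2 therefore stands nowhere that can be ranked: its result is a limit, and the one further value shown is a limit as well, so no step between measured compounds can be drawn.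

Compound 3, `CC[C@]1(OC)CCC2(CO1)[C@@H]1CCC3=C4[C@@H](CC3=O)[C@H](C(=O)OC)C[C@@]42CN(C)C1`, is the next compound. Its change from compound 2 is small: the two compounds have the same atoms and bonds; at least one stereo element is drawn with a configuration in one of them and without one in the other: 1 of 6 stereo elements differ; a stereocentre at a saturated ring carbon is drawn R in compound 2 and S in compound 3. Among the measured compounds shown here, the two measured compounds give no step from which the size of such a change could be read. The expectation is that the change will produce no shift beyond the usual scatter, and that compound 3 will again come out at the limit. Compound 3 is expected to give 40000 nM, with a range from 20000 nM to 80000 nM. That estimate means an expected step of a number no higher from compound 2 to compound 3 (the limit leaves the size open).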

Compound 3, half-maximal inhibitory concentration: > 40000 nM
Compound 3: only a limit was reported; the forecaster's own chance of this, stated with the estimate: 85%; the middle value sits exactly at the limit.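

In this assay compound 3 gives > 40000 nM, which is again a limit and not a number. No step from compound 1 or compound 2 to compound 3 can be read, because all three results are limits: the limit of > 40000 nM in this assay, at which 3 of the 3 values shown sit.

The compounds shown leave open what number any of the three would reach, and whether the drawn stereocentre has any effect on it.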